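This account rests on a few compounds, and the source may have more. Where it says the series, first, only, none or still open, it means among the compounds named here.

Series notes: compounds sharing one amide-linked core, tested in an in vitro assay on cells for inhibition of Amine oxidase [flavin-containing] B (Homo sapiens), read by fluorescence and Amplex Red, with stated times of 30 min and 45 min; a higher number here means a weaker inhibitor, a lower number a stronger inhibitor. Compound 1 `COc1cccc(CCCC(=O)Nc2nc3ccccc3c(=O)s2)c1` gives 389 nM in this assay. Compound 2 `O=C(C/C=C/c1ccccc1)Nc1nc2ccccc2c(=O)s1` gives 39.8 nM in this assay, the lowest of the two numbers reported, with the step from compound 1 to compound 2 beyond the scatter. Compound 3 `O=C(Nc1nc2ccccc2c(=O)s1)c1ccccc1` gives "not determined" (no result reported) in this assay, that is, no result reported.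

Compound 4 `O=C(C/C=C/c1ccc(Cl)c(Cl)c1)Nc1nc2ccccc2c(=O)s1` is next to be measured in this assay. It differs from compound 2 by 3,4-dichlorophenyl in place of phenyl on a double-bonded chain carbon bound to a double-bonded chain carbon. With no measured step of this kind in the set, the size of the change is uncertain; a modest improvement, near the edge of the scatter, is expected. Compound 4 is estimated at 25 nM, range 8 nM to 80 nM, which means an expected step of a 1.6-fold lower number from compound 2 to compound 4 (0.20 log units; within the scatter).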

Compound 4, half-maximal inhibitory concentration: > 10000 nM
Compound 4: a limit, no number; the forecaster's own chance of this, stated with the estimate: 5%; middle value at least 400-fold (2.60 log units) away from the limit.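

Compound 4 gives a limit of the assay, not a number: the limit of > 10000 nM in this assay, at which 1 of the 4 values shown sits. In this assay, 3,4-dichlorophenyl in place of phenyl on a double-bonded chain carbon bound to a double-bonded chain carbon gives an at least 250-fold higher number from compound 2 to compound 4 (2.40 log units; beyond the scatter). Within the data shown here, this is the first single-place step, and it shows that this position is sensitive: the change of this ring alone takes the reading from the low end of the set to the assay limit.

As far as these compounds go, it remains open whether a phenyl ring carrying one chlorine, or a pyridyl ring in place of phenyl, would stay near compound 2. From the compounds shown here alone, whether a methoxy group on this ring would do the same is also open.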